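Replacing the Aryl Group on the Shared Core

The source may hold more compounds than are shown below. What is called first, only, known or untested is meant among the compounds shown, and "the series" means these compounds.

compound 1 `Cc1ccc(S(=O)(=O)NN2C(=S)S/C(=C\c3ccc(Cl)c(Cl)c3)C2O)cc1`: > 100000 nM in a functional assay on HFF cells (Homo sapiens) for cytotoxicity (on this read-out lower numbers stand for stronger inhibition and higher numbers for weaker inhibition), a limit of the assay
compound 2 `O=S(=O)(NN1C(=S)S/C(=C\c2ccc(Cl)c(Cl)c2)C1O)c1ccc(Cl)cc1`: > 100000 nM, a limit of the assay
compound 3 `O=C1/C(=C/c2ccc([N+](=O)[O-])cc2)SC(=S)N1NS(=O)(=O)c1ccccc1`: > 100000 nM, a limit of the assay

Compound 3 therefore stands only at a limit, and the same holds for every value shown, since (the limit of > 100000 nM in this assay, at which 3 of the 3 values shown sit). Within the data shown here, the single measured step, a step that the two limits leave unreadable from compound 1 to compound 2, is left unreadable by the two limits, and it lies at a different place on the shared core. Compound 4 `Cc1ccc(/C=C2\SC(=S)N(NS(=O)(=O)c3ccccc3)C2=O)cc1C` differs from compound 3 by 3,4-dimethylphenyl in place of 4-nitrophenyl on a double-bonded chain carbon bound to a double-bonded ring carbon. Among the measured compounds shown here, no measured step bears on this change, so nothing beyond the scatter is expected in this assay, and compound 4 is expected to remain at the limit. The estimate for compound 4 is 100000 nM, from 50000 nM to 300000 nM. The expected step is a number no higher from compound 3 to compound 4 (the limit leaves the size open).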

Compound 4, half-maximal inhibitory concentration: > 100000 nM
Compound 4: a limit, no number; the forecaster's own chance of this, stated with the estimate: 80%; the middle value sits exactly at the limit.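

In this assay, among these compounds, compound 4 gives > 100000 nM, a limit of the assay, so no step from compound 3 to compound 4 can be read. The compounds shown leave open what any change on the shared core does to the read-out, as all of them rest on one value: the limit of > 100000 nM in this assay, at which 4 of the 4 values shown sit.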